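The source may report more compounds than this note shows. Statements on the series, on what has been measured and on what is new or still open speak of the compounds shown alone.

Measured compounds and their values:
- compound 1, `COc1cc(-c2cc(/C=C/C(=O)c3ccc(N)cc3)[nH]n2)cc(OC)c1OC`: 91%
- compound 2, `COc1ccc(-c2cc(/C=C/C(=O)c3ccc(N)cc3)[nH]n2)cc1OC`: 97%
- compound 3, `COc1ccc(-c2cc(/C=C/C(=O)c3cc(OC)c(OC)c(OC)c3)[nH]n2)cc1OC`: 91%

In a functional assay on CCRF-CEM cells (Homo sapiens) for cytotoxicity, read by sulforhodamine B assay, with a stated time of 48 h, tested at 0.1 uM (on this read-out higher numbers stand for a weaker effect at the one concentration tested and lower numbers for a stronger effect), compound 1 gives 91%. This is level, at the digits given, with compound 3, and together they are the lowest of the three numbers; compound 2 stands furthest away, yet the step of a number 6 percentage points higher from compound 1 to compound 2 (within the scatter) lies within the scatter. So on the numbers shown, all three compounds look alike.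

Compound 4, `COc1ccc(C(=O)/C=C/c2cc(-c3cc(OC)c(OC)c(OC)c3)n[nH]2)cc1`, is not yet measured. It differs from compound 1 in one place:

methoxy in place of amino on an aromatic carbon

For the measured compounds named here, none of the measured steps is the same change. Going by the values given here, the one measured step, a number 6 percentage points higher from compound 1 to compound 2 (within the scatter), concerns a different group and was small. Compound 3 carries a quite different ring in this position and gives 91%, again the same as compound 1. With every measured number lying close together, there is no ground to expect that swapping amino for methoxy moves this assay beyond the scatter in either direction.

Compound 4 is therefore expected to give about 93%, between 80% and 103%, which would mean an expected step of a number 2 percentage points higher from compound 1 to compound 4 (within the scatter).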

Compound 4, a percentage reported as activity, at one concentration (the size of the read-out at that concentration, not a potency): 98%
Compound 4: the middle estimate sits 5 percentage points below what was measured, within the range that was stated.
By their numbers in this assay, from the lowest: compounds 1, 3, 2 and 4 (each within the scatter of the next).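

In this assay, putting methoxy in place of amino on the aromatic ring, para to a large group, gives a number 7 percentage points higher from compound 1 to compound 4 (within the scatter), so this position has now been tested directly and the change does not separate the two compounds. The swap replaces a group with 1 hydrogen-bond donor by one with 0 hydrogen-bond donors and goes from 4-aminophenyl to 4-methoxyphenyl, yet the step stays within the usual scatter, so neither group can be preferred here on this read-out. No independent measurement is available to explain why the result stays flat at this position.

Going by these compounds, whether any group at this place can move the number beyond the scatter remains open, and a hydroxyl, a dimethylamino group or a carboxylic acid on the same ring carbon would test that further. Because all of these compounds were read at a single concentration in this assay, it also remains open whether amino and methoxy would still look alike at other concentrations.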